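The source may report more compounds than this note shows. Statements on the series, on what has been measured and on what is new or still open speak of the compounds shown alone.

Measured so far:
compound 1, `COc1cccc(OC)c1OCCNCCOc1ccccc1OCc1cccc(Cl)c1` — 5900 nM
compound 2, `COc1cccc(OC)c1OCCNCCOc1ccccc1OCc1ccc(Cl)cc1` — 2400 nM
compound 3, `COc1cccc(COc2ccccc2OCCNCCOc2c(OC)cccc2OC)c1` — 2500 nM

These values come from a functional assay on PC-3 cells (Homo sapiens) for cytotoxicity, read by sulforhodamine B assay; a higher number here means a weaker inhibitor of growth, a lower number a stronger inhibitor of growth. Compound 3 stands second highest of the three numbers: the step of a 1.0-fold higher number from compound 2 to compound 3 (0.02 log units; within the scatter) lies within the scatter, while the step of a 2.4-fold lower number from compound 1 to compound 3 (0.37 log units; beyond the scatter) lies beyond it.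

Compound 4, `COc1cccc(OC)c1OCCNCCOc1ccccc1OCc1ccc(OC(C)C)cc1`, differs from compound 3 by 4-isopropoxyphenyl in place of 3-methoxyphenyl on a saturated chain carbon bound to an oxygen on an aromatic ring. Within the data shown here, two measured steps bear on this part of the molecule: a 2.5-fold lower number from compound 1 to compound 2 (0.39 log units; beyond the scatter) and a 1.0-fold higher number from compound 2 to compound 3 (0.02 log units; within the scatter), one modest, one within the scatter. Among the measured compounds shown here, no measured step tests an isopropoxy group at all. A small step in this assay is therefore expected, at most a modest lowering, plausibly none beyond the scatter. The estimated step is a 1.3-fold lower number from compound 3 to compound 4 (0.10 log units; within the scatter). Compound 4 is expected to give about 2000 nM, between 800 nM and 5000 nM.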

Compound 4, concentration for 50% growth inhibition: 2000 nM
Estimate against measurement, compound 4: no gap at the digits printed; the measured number falls inside the stated range.
By their numbers in this assay, from the lowest: compounds 4, 2 and 3 (each within the scatter of the next); then compound 1.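

In this assay the 4-isopropoxyphenyl group, with 10 heavy atoms against 8 in 3-methoxyphenyl, is accepted at this position: the steps of a 1.3-fold lower number from compound 3 to compound 4 (0.10 log units; within the scatter) and a 1.2-fold lower number from compound 2 to compound 4 (0.08 log units; within the scatter) stay within the scatter. Among these compounds, the 3-chlorophenyl compound remains apart from this group, with a 3.0-fold lower number from compound 1 to compound 4 (0.47 log units; beyond the scatter) as the largest step so far. No measurement here explains these differences. Still open, as far as these compounds go, is whether an amine or a carboxylic acid at this position would change the number, and whether a longer chain in place of isopropoxy would.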